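This account rests on a few compounds, and the source may have more. Where it says the series, first, only, none or still open, it means among the compounds named here.

Compound 2 `O=[N+]([O-])c1cccc(CSc2nnc(-c3ccc4c(c3)OCCO4)n2-c2ccccc2)c1` is the weakest-looking of the three measured compounds in a functional assay on HepG2 cells (Homo sapiens) for antiproliferative activity, read by MTT assay, with a stated time of 24 h; a higher number here means a weaker inhibitor, a lower number a stronger inhibitor: compound 2 gives 49300 nM, whereas compound 1 `c1ccc(CSc2nnc(-c3ccc4c(c3)OCCO4)n2-c2ccccc2)cc1` gives 5960 nM and compound 3 `COc1cccc(CSc2nnc(-c3ccc4c(c3)OCCO4)n2-c2ccccc2)c1` gives 35100 nM. The step of an 8.3-fold higher number from compound 1 to compound 2 (0.92 log units; beyond the scatter) and the step of a 5.9-fold higher number from compound 1 to compound 3 (0.77 log units; beyond the scatter) both lie beyond the scatter, while the step of a 1.4-fold lower number from compound 2 to compound 3 (0.15 log units; within the scatter) does not. Compound 4 `Brc1cccc(CSc2nnc(-c3ccc4c(c3)OCCO4)n2-c2ccccc2)c1` differs from compound 2 by bromo in place of nitro on an aromatic carbon. Among the measured compounds shown here, no measured step swaps one substituent for another at that place apart from the one from compound 2 to compound 3, which stayed within the scatter, so the only guide is that both groups tried so far gave higher numbers than hydrogen in this assay. Bromo is therefore expected to land near the two substituted compounds, perhaps somewhat lower, and the step from compound 2 to compound 4 is estimated as a 2.5-fold lower number from compound 2 to compound 4 (0.39 log units; beyond the scatter). For compound 4 the expected value in this assay is 20000 nM, with a range from 6000 nM to 60000 nM.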

Compound 4, half-maximal inhibitory concentration: 5210 nM
Compound 4: the middle estimate sits 3.8-fold (0.58 log units) above what was measured; measured number outside the range, below it.
By their numbers in this assay, from the lowest: compounds 4 and 1 (each within the scatter of the next); then compounds 3 and 2 (each within the scatter of the next).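

In this assay, a substituent at this place does not always give a higher number than hydrogen: with a 1.1-fold lower number from compound 1 to compound 4 (0.06 log units; within the scatter) as the step, bromo stays within the scatter of hydrogen, while nitro and methoxy both gave higher numbers. The choice of substituent also matters here, which the step between nitro and methoxy alone could not show, since both a 9.5-fold lower number from compound 2 to compound 4 (0.98 log units; beyond the scatter) and a 6.7-fold lower number from compound 3 to compound 4 (0.83 log units; beyond the scatter) lie beyond the scatter. Nothing at hand bears on why bromo parts from nitro and methoxy.

From the compounds shown here alone, whether this behaviour is particular to bromo or extends to chloro or fluoro remains open, as does whether a methyl group or an amine here would fall with hydrogen and bromo or with nitro and methoxy. The compounds also leave open how bromo would behave elsewhere on the benzyl group.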